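Replacing oxan-4-yl with an amino-alcohol chain

The source may report more compounds than this note shows. Statements on the series, on what has been measured and on what is new or still open speak of the compounds shown alone.

Compound 1 `N=C(Nc1ccc2c(c1)N(C1CCCCC1)CC2)c1cccs1` and compound 2 `N=C(Nc1ccc2c(c1)N(C1CCOCC1)CC2)c1cccs1` share one core and differ only in the group carried by the nitrogen on the aromatic ring in the ring. In an in vitro assay on Sf9 cells for inhibition of Nitric oxide synthase, inducible (Homo sapiens), read by scintillation counting, with stated times of 15 min and 45 min (a higher number here means a weaker inhibitor, a lower number a stronger inhibitor), compound 1 gives > 100000 nM, which is a limit of the assay and not a number. In this assay compound 2 likewise gives > 100000 nM, again a limit rather than a measured number. The step that the two limits leave unreadable from compound 1 to compound 2 therefore cannot be read, and compound 2 stands nowhere more exactly than at the limit of > 100000 nM in this assay, at which 2 of the 2 values shown sit.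

Compound 3 `N=C(Nc1ccc2c(c1)N(CCNCCO)CC2)c1cccs1` carries the change (2-((2-hydroxyethyl)amino)ethyl in place of oxan-4-yl on a nitrogen on an aromatic ring in a ring). Among the measured compounds shown here, no measured step bears directly on this change: the only step recorded, from cyclohexyl to oxan-4-yl, is itself hidden by the two limits, so there is no measured size to carry over. With both measured compounds sitting at the limit, the step of a number no higher from compound 2 to compound 3 (the limit leaves the size open) is expected to stay within the scatter, with no clear direction. Compound 3 is therefore estimated at 100000 nM, with a range from 30000 nM to 300000 nM, and it is expected that this assay may again report only a limit for compound 3.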

Compound 3, half-maximal inhibitory concentration: 3410 nM
Estimate against measurement, compound 3: 29-fold (1.47 log units) above; measured number outside the range, below it.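

The 2-((2-hydroxyethyl)amino)ethyl chain on the nitrogen gives in this assay an at least 29-fold lower number from compound 2 to compound 3 (1.46 log units; beyond the scatter), and set against cyclohexyl it gives an at least 29-fold lower number from compound 1 to compound 3 (1.46 log units; beyond the scatter). The earlier change at this place, from cyclohexyl to oxan-4-yl, could not be read, so those compounds did not show that the group here can matter at all; of the three groups shown, only the open chain gives a measured number, while the two ring-bearing compounds stay at a limit of the assay: the limit of > 100000 nM in this assay, at which 2 of the 3 values shown sit. The chain has the same heavy-atom count as oxan-4-yl, so this large step comes without any change in that count, though the ring is lost and a nitrogen and more hydrogen-bond donors enter.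

The compounds shown change all of these features at once, and they do not tell whether the nitrogen, the hydroxyl or the loss of the ring accounts for the step. A plain 2-aminoethyl chain, a chain ending in a methoxy group, a longer amino-alcohol chain or a piperidin-4-yl ring would each separate these features, and none of these is among the compounds shown.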